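Methoxy in place of fluoro on the shared core

The source may hold more compounds than are shown below. What is called first, only, known or untested is meant among the compounds shown, and "the series" means these compounds.

In a functional assay on HCT-116 cells (Homo sapiens) for inhibition, read by colorimetric assay, with a stated time of 3 days (a lower number here means a stronger inhibitor, a higher number a weaker inhibitor), compound 3 `O=C(CCCCCCNC(=O)C(O)(O)C(F)(F)F)Nc1nc2ccc(F)cc2s1` gives 6470 nM. Compound 1 `COc1ccc(OC)c(NC(=O)CCCCCCNC(=O)C(O)(O)C(F)(F)F)c1` gives 3870 nM, and compound 2 `O=C(CCCCCCNC(=O)C(O)(O)C(F)(F)F)Nc1nc2ccc(Cl)cc2s1` gives 11000 nM. Compound 3 holds the middle of these three numbers, and its gap to each of the other two lies within the usual scatter.

Compound 4 `COc1ccc2nc(NC(=O)CCCCCCNC(=O)C(O)(O)C(F)(F)F)sc2c1` keeps the core and chain of compound 3 and changes one group: methoxy in place of fluoro on an aromatic carbon. In words, this is methoxy in place of fluoro on an aromatic carbon. Among the compounds with values here, only one measured step swaps a group on this core: a 1.7-fold lower number from compound 2 to compound 3 (0.23 log units; within the scatter). Within the data shown here, that swap did not move the number beyond the scatter, but it involved no methoxy group, so the data contain no direct precedent for this change. Compound 1 does carry methoxy, on a different core, and its 3870 nM stays within the scatter of compound 3. No step beyond the scatter is therefore expected in this assay, and these data give no firm direction. The estimated change is a 1.1-fold lower number from compound 3 to compound 4 (0.03 log units; within the scatter). Compound 4 is expected at about 6000 nM, with an estimated range of 2500 nM to 14000 nM.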

Compound 4, half-maximal inhibitory concentration: 7560 nM
The estimate for compound 4 lay 1.3-fold (0.10 log units) below the measured number; low and high end bracket the measured number.
By their numbers in this assay, from the lowest: compounds 1, 3, 4 and 2 (each within the scatter of the next, the first and the last beyond it).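

In this assay, the change gives a 1.2-fold higher number from compound 3 to compound 4 (0.07 log units; within the scatter), and the comparison with the chloro analogue gives a 1.5-fold lower number from compound 2 to compound 4 (0.16 log units; within the scatter), so neither step leaves the scatter. The earlier step on this shared core exchanged only one halogen for another, whereas these steps put a group that is not a halogen at the same aromatic carbon: methoxy, which is larger than fluoro and adds a hydrogen-bond acceptor. Fluoro, chloro and methoxy at this place therefore give numbers that cannot be told apart in this cell assay, and nothing measured here explains that closeness.

On these data alone, it remains open whether an amine, a hydroxyl group or a carboxylic acid at this aromatic carbon would also stay within the scatter, or whether any group here can move the number beyond it. The compounds shown also leave open whether a longer alkoxy group, such as ethoxy, or a change in the chain joining the shared core to the hydrated trifluoroacetyl end would have a larger effect.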